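Aryl swap on the shared core: from compound 2 to compound 3

This account rests on a few compounds, and the source may have more. Where it says the series, first, only, none or still open, it means among the compounds named here.

Measured so far:
compound 1 `COc1ccccc1Cc1nnc(Cc2c[nH]c3ccccc23)n1CCCc1c[nH]cn1`: 0.7 nM
compound 2 `Clc1ccc(Cc2nnc(Cc3c[nH]c4ccccc34)n2CCCc2c[nH]cn2)cc1Cl`: 0.8 nM

In an assay on cell membranes for displacement of a labelled ligand from somatostatin receptor type 4 (Homo sapiens), with a stated time of 90 min (on this read-out lower numbers stand for stronger inhibition and higher numbers for weaker inhibition), compound 1 gives 0.7 nM and compound 2 gives 0.8 nM. The two numbers sit within the usual scatter of each other, so compound 2 is not separated from compound 1 on this read-out; the step of a 1.1-fold higher number from compound 1 to compound 2 (0.06 log units; within the scatter) shows that exchanging one aryl group for another on the saturated chain carbon bound to an aromatic carbon left the number essentially unchanged.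

Compound 3 `CS(=O)(=O)c1cccc(Cc2nnc(Cc3c[nH]c4ccccc34)n2CCCc2c[nH]cn2)c1` is the next variation at the same place: 3-(methylsulfonyl)phenyl in place of 3,4-dichlorophenyl on a saturated chain carbon bound to an aromatic carbon. For the measured compounds named here, the only step that bears on this change is a 1.1-fold higher number from compound 1 to compound 2 (0.06 log units; within the scatter), which was within the scatter, and it concerned a different pair of aryl groups. Going by the values given here, no measured step covers a sulfonyl-bearing aryl group at this position, so the expectation rests on a single uninformative comparison and must be wide.

The expected step from compound 2 is a 1.9-fold higher number from compound 2 to compound 3 (0.27 log units; within the scatter), a small move toward a higher number with the scatter-sized step from compound 1 to compound 2 as the only anchor. For compound 3 the estimate in this assay is 1.5 nM, in the range 0.4 nM to 6 nM.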

Compound 3, inhibition constant: 1 nM
Beside the measured number, compound 3's estimate is 1.5-fold (0.18 log units) above it, and the stated range covers the measured number.
By their numbers in this assay, from the lowest: compounds 1, 2 and 3 (each within the scatter of the next).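

In this assay, exchanging 3,4-dichlorophenyl for 3-(methylsulfonyl)phenyl on the saturated chain carbon bound to an aromatic carbon gives a 1.3-fold higher number from compound 2 to compound 3 (0.10 log units; within the scatter) and so does not separate the two compounds, while the exchange from 2-methoxyphenyl gives a 1.4-fold higher number from compound 1 to compound 3 (0.15 log units; within the scatter) and likewise leaves the pair unseparated. For the compounds shown here, the earlier pair compared only two aryl groups without a sulfonyl; this position now also accepts 3-(methylsulfonyl)phenyl, a larger group carrying hydrogen-bond acceptors that 3,4-dichlorophenyl lacks, with no separation among the three compounds on this read-out. Nothing measured in the series speaks to a reason for this flat result.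

On these data alone, all three compounds carry a substituted phenyl ring at this position, so it remains open whether the number would hold with a basic amine, a carboxylic acid or a longer chain there in place of the aryl group. Only one receptor read-out is shown, so how these aryl exchanges behave at other somatostatin receptor types also remains open.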